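This account rests on a few compounds, and the source may have more. Where it says the series, first, only, none or still open, it means among the compounds named here.

Working notes on the series. In an in vitro ADME assay on microsomes from liver (Homo sapiens) for metabolic stability, read by LC-MS, tested at 1 uM (on this read-out higher numbers stand for fast clearance and lower numbers for slow clearance), compound 1 `COCCN(C)S(=O)(=O)c1ccc(C)c(C#Cc2cc(Cl)ccc2OCC(=O)O)c1` gives 32 mL.min-1.g-1. Compound 2 `Cc1ccc(S(=O)(=O)N(C)C)cc1C#Cc1cc(Cl)ccc1OCC(=O)O` is reported only as a limit, < 10 mL.min-1.g-1. Its exact place on the scale is therefore unknown, and any comparison with it can only be made against that limit.

Compound 3 `Cc1ccc(S(C)(=O)=O)cc1C#Cc1cc(Cl)ccc1OCC(=O)O` keeps the core of compound 2 and changes one group: methyl in place of dimethylamino on a sulfonyl sulfur. This is methyl in place of dimethylamino on a sulfonyl sulfur, or, cut one bond further out, dimethylsulfamoyl to methylsulfonyl.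

Among the measured compounds shown here, only one measured step lies near this change, an at least 3.2-fold lower number from compound 1 to compound 2 (0.50 log units; beyond the scatter). That step replaces methoxymethyl with hydrogen on a saturated chain carbon bound to a sulfonamide nitrogen, so it bears on the new change only indirectly. For the measured compounds named here, no measured step replaces the dimethylamino group itself. Going by the values given here, with only that indirect step as a guide, no step beyond the scatter is expected in this assay, and clearance is expected to stay slow.

The expected step is a step that the limit leaves unreadable from compound 2 to compound 3. For compound 3 the estimate is 8 mL.min-1.g-1, with an expected range of 4 mL.min-1.g-1 to 20 mL.min-1.g-1.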

Compound 3, intrinsic clearance in microsomes: 14 mL.min-1.g-1
Estimate against measurement, compound 3: 1.8-fold (0.24 log units) below; the range from low to high includes it.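

In this assay the sulfonyl sulfur accepts methyl in place of the (2-methoxyethyl)(methyl)amino group of compound 1, with the comparison giving a 2.3-fold lower number from compound 1 to compound 3 (0.36 log units; beyond the scatter). Against the smaller dimethylamino group the reading is an at least 1.4-fold higher number from compound 2 to compound 3 (0.14 log units; that floor lies within the scatter), so the floor of that step does not establish a difference beyond the scatter. Of the compounds shown, only compound 3 has no nitrogen on the sulfonyl sulfur, so the drop from the number of compound 1 does not require a sulfonamide to be kept at this position.

The true distance between compound 2 and compound 3 stays unreadable because compound 2 stands only as a limit: the limit of < 10 mL.min-1.g-1 in this assay, at which 1 of the 3 values shown sits. Also open, on these data alone, is whether a cyclic amine such as morpholine or a longer chain such as ethyl on the sulfonyl sulfur would read with compound 3 or with compound 1 on this scale.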